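Trimming a Dimethylamino Group: Expected Acid Dissociation

The source may report more compounds than this note shows. Statements on the series, on what has been measured and on what is new or still open speak of the compounds shown alone.

In a physicochemical assay for acid dissociation, compound 1 `COc1ccc(F)cc1CNCCCNc1ccnc2cc(-c3ccc(F)cc3)ccc12` gives 9.47.
In this assay compound 2 `COc1ccc(F)cc1CNCCCNc1ccnc2cc(Oc3cccc(N(C)C)c3)ccc12` gives 9.28.
In this assay compound 3 `COc1cccc(CNCCCNc2ccnc3cc(Oc4cccc(N(C)C)c4)ccc23)c1O` gives 9.28.

Compound 2 stands level with compound 3 at the digits shown, and together they are the lowest of the three numbers; compound 1 is the furthest away. Both recorded steps stay within the scatter: a number 0.19 log units lower from compound 1 to compound 2 (within the scatter), and no change at the digits printed from compound 2 to compound 3 (within the scatter).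

Compound 4 `COc1ccc(F)cc1CNCCCNc1ccnc2cc(Oc3ccccc3)ccc12` differs from compound 2 by hydrogen in place of dimethylamino on an aromatic carbon. Of the measured steps, the one touching this part of the molecule is a number 0.19 log units lower from compound 1 to compound 2 (within the scatter); the other, no change at the digits printed from compound 2 to compound 3 (within the scatter), changes a distant part. Neither crossed the scatter, so a step of a number 0.02 log units higher from compound 2 to compound 4 (within the scatter) is expected, nothing beyond the scatter. For compound 4 the estimate in this assay is 9.3, ranging from 9 to 9.6.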

Compound 4, acid dissociation constant: 9.28
Estimate against measurement, compound 4: 0.02 log units above, within the range that was stated.
By their numbers in this assay, from the lowest: compounds 2, 3, 4 and 1 (each within the scatter of the next).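

In this assay, hydrogen in place of dimethylamino gives no change at the digits printed from compound 2 to compound 4 (within the scatter). Compounds 1, 2 and 3 could not show this, as neither compound carrying the phenoxy linkage lacked the dimethylamino group. Phenoxy in place of 4-fluorophenyl gives a number 0.19 log units lower from compound 1 to compound 4 (within the scatter), so this comparison also stays within the scatter without the dimethylamino group. No other data here bear on the reason for these readings. Still open, from the compounds shown here alone, is whether a carboxylic acid or a primary amine at this place on the ring would also stay within the scatter.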